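Swapping a Butyl Chain for a Methoxyphenyl Ring

A few compounds are considered here, and "the series" means these few. Any claim that something is new, unique, unknown or untested is made for them only; others in the source may bear on it.

Of the compounds shown here, three sharing a common core have been tested in a functional assay on KB cells (Homo sapiens) for cytotoxicity, read by MTT assay, with a stated time of 72 h; on this read-out higher numbers stand for weaker inhibition and lower numbers for stronger inhibition. Compound 1 `CCCOCNc1n[n+]([O-])c2cc(OC)ccc2[n+]1[O-]` gives 3200 nM, compound 2 `COc1ccc2c(c1)[n+]([O-])nc(NCOC(C)c1ccccc1)[n+]2[O-]` gives 220 nM, and compound 3 `CCCCCOCNc1n[n+]([O-])c2ccccc2[n+]1[O-]` gives 1220 nM. In this assay compound 3 therefore sits in the middle of the three: compound 1 shows a higher number and compound 2 a lower one.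

The step of interest moves from compound 3 to compound 4 `COc1ccc(COCNc2n[n+]([O-])c3ccccc3[n+]2[O-])cc1`, which is not yet measured. The change is 4-methoxyphenyl in place of butyl on a saturated chain carbon bound to an oxygen on a saturated carbon.

One measured step resembles it: placing an aromatic ring where a short alkyl chain stood gave a 15-fold lower number from compound 1 to compound 2 (1.16 log units; beyond the scatter). Within the data shown here, that is the only guidance here, and it was made on a core carrying a methoxy group, whereas compound 3 and compound 4 lack it, so the size is uncertain. On that basis compound 4 is expected to show a clearly lower number in this assay, about a 6.1-fold lower number from compound 3 to compound 4 (0.79 log units; beyond the scatter). The estimate for compound 4 is 200 nM, with a range from 60 nM to 700 nM.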

Compound 4, half-maximal inhibitory concentration: 4060 nM
Beside the measured number, compound 4's estimate is 20-fold (1.31 log units) below it; measured number outside the range, above it.
By their numbers in this assay, from the lowest: compound 2; then compound 3; then compounds 1 and 4 (each within the scatter of the next).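

In this assay, 4-methoxyphenyl in place of butyl on this saturated chain carbon gives a 3.3-fold higher number from compound 3 to compound 4 (0.52 log units; beyond the scatter), so a ring in place of a chain does not by itself bring a lower number at this position. The earlier ring-for-chain swap, a 15-fold lower number from compound 1 to compound 2 (1.16 log units; beyond the scatter), went the opposite way, which means the two steps disagree in direction, though they differ in both the entering group and the core. No measurement available here gives a reason for the rise in this step.

As far as these compounds go, it remains open whether 4-methoxyphenyl would raise or lower the number on the methoxy-bearing core of compound 1, which would help separate the effect of the group from that of the core. Also open, from the compounds shown here alone, is how a longer chain than butyl, or a ring carrying an amine instead of methoxy, would behave here.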